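A few compounds are considered here, and "the series" means these few. Any claim that something is new, unique, unknown or untested is made for them only; others in the source may bear on it.

Working notes on the cytotoxicity series. The read-out is an ADME assay on RAW264.7 cells (Mus musculus) for cytotoxicity, with a stated time of 24 h; on this read-out lower numbers stand for stronger inhibition and higher numbers for weaker inhibition. Compound 2 `COc1ccc(-c2cc(-c3ccc4c(c3)CCCC4)nc(OCC(=O)NCc3ccccc3)c2C#N)cc1OC` gives 8400 nM in this assay and stands lowest of the two numbers recorded so far; compound 1 `CC(C)c1ccc(-c2cc(-c3ccc4c(c3)CCCC4)nc(OCC(=O)NN)c2C#N)cc1` gives 27700 nM in this assay, a gap that lies beyond the usual scatter. Among the compounds with values here, compound 1 and compound 2 differ in two places, so no single step between them can be read off.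

Compound 3 `CC(C)c1ccc(-c2cc(-c3ccc4c(c3)CCCC4)nc(OCC(=O)NCc3ccccc3)c2C#N)cc1` has not yet been measured. It differs from compound 2 by 4-isopropylphenyl in place of 3,4-dimethoxyphenyl on an aromatic carbon. Within the data shown here, the 4-isopropylphenyl group that enters is the one also present in compound 1, although compound 3 differs from compound 1 elsewhere, so the number of compound 1, 27700 nM, is only a loose pointer.

Among the measured compounds shown here, with only two numbers and no matched pair, a step of modest size toward a higher number is expected for a 1.8-fold higher number from compound 2 to compound 3 (0.25 log units; within the scatter), possibly not clearly beyond the scatter. For compound 3 the expected value in this assay is 15000 nM, with a range from 5000 nM to 45000 nM.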

Compound 3, half-maximal inhibitory concentration: 9900 nM
The estimate for compound 3 lay 1.5-fold (0.18 log units) above the measured number; the range from low to high includes it.
By their numbers in this assay, from the lowest: compounds 2 and 3 (each within the scatter of the next); then compound 1.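

In this assay, 4-isopropylphenyl in place of 3,4-dimethoxyphenyl on the aromatic carbon opposite the ring nitrogen gives a 1.2-fold higher number from compound 2 to compound 3 (0.07 log units; within the scatter) and so leaves the read-out within the scatter, even though the group that leaves has 2 hydrogen-bond acceptors and the group that enters has none. Within the data shown here, at the amide-type nitrogen, benzyl in place of amino gives a 2.8-fold lower number from compound 1 to compound 3 (0.45 log units; beyond the scatter) and this modest step lies beyond the scatter, so of the two places now read singly, only this one shows a step that clears it. No evidence on hand accounts for either step.

Going by these compounds, the two aryl groups at the aromatic carbon are both six-membered carbon rings, so it remains open whether a phenyl group carrying an amine or a carboxylic acid, or a small alkyl group such as methyl in place of the ring, would also stay within the scatter of compound 3. At the amide-type nitrogen, only amino and benzyl are shown, which leaves open how a longer chain such as phenethyl, or a simple methyl group, would read in this assay against these two.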